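A Methoxy Group Added to the 2-Phenylethenyl Amide

The compounds below may be only part of what the source reports. "The series", "measured", "known", "first", "only" and "open" are said of these compounds alone.

Measured compounds:
Compound 1, `CN1[C@@H]2c3[nH]c4ccccc4c3C[C@H]1[C@H](C#N)N1[C@@H](CNC(=O)c3cccc4c3CCCC4)c3[nH]c4ccccc4c3C[C@@H]21`, gives 3340 nM in a functional assay on HT-29 cells (Homo sapiens) for cytotoxicity, read by MTT assay, with a stated time of 72 h; a lower number here means a stronger inhibitor, a higher number a weaker inhibitor.
Compound 2, `CN1[C@@H]2c3[nH]c4ccccc4c3C[C@H]1[C@H](C#N)N1[C@@H](CNC(=O)/C=C/c3ccccc3)c3[nH]c4ccccc4c3C[C@@H]21`, gives 1400 nM in this assay.

Compound 2 holds the lowest of the two numbers in this assay. For the measured compounds named here, the only measured step, a 2.4-fold lower number from compound 1 to compound 2 (0.38 log units; beyond the scatter), separates it from compound 1 and lies beyond the scatter.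

Compound 3, `COc1ccc(/C=C/C(=O)NC[C@H]2c3[nH]c4ccccc4c3C[C@H]3[C@H]4c5[nH]c6ccccc6c5C[C@@H]([C@H](C#N)N23)N4C)cc1`, is the next compound and has not yet been measured in this assay. It differs from compound 2 by methoxy in place of hydrogen on an aromatic carbon, para to a large group.

Going by the values given here, no measured step bears directly on this change. Among the compounds with values here, the single step measured so far exchanged the whole group on the carbonyl carbon, not a substituent on the aromatic ring, so it offers no guide to the size or direction of this smaller change. The expectation is therefore for a step within the scatter, in neither direction, and compound 3 is estimated at 1300 nM, with a range from 500 nM to 3500 nM, which means an expected step of a 1.1-fold lower number from compound 2 to compound 3 (0.03 log units; within the scatter).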

Compound 3, half-maximal inhibitory concentration: 3060 nM
Estimate against measurement, compound 3: 2.4-fold (0.37 log units) below; low and high end bracket the measured number.
By their numbers in this assay, from the lowest: compound 2; then compounds 3 and 1 (each within the scatter of the next).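

In this assay, the first substituent on this aromatic ring has a measurable effect: methoxy in place of hydrogen on an aromatic carbon, para to a large group, gives a 2.2-fold higher number from compound 2 to compound 3 (0.34 log units; beyond the scatter) and so costs compound 3 the advantage that the 2-phenylethenyl amide had held. The comparison with the other amide shows this directly, as a 1.1-fold lower number from compound 1 to compound 3 (0.04 log units; within the scatter) leaves the 2-(4-methoxyphenyl)ethenyl and 1,2,3,4-tetrahydronaphthalen-5-yl groups on the carbonyl carbon indistinguishable in this assay, whereas a 2.4-fold lower number from compound 1 to compound 2 (0.38 log units; beyond the scatter) had separated the unsubstituted 2-phenylethenyl group from the latter. No information is available to explain why this small addition moves the number by about as much as exchanging the whole group on the carbonyl carbon.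

The compounds shown offer a single substituent at a single place, so it remains open whether a hydroxy group, a fluorine atom or a chlorine atom on the same aromatic carbon would also raise the number. On these data alone, it also remains open whether the step belongs to methoxy specifically or would recur with a longer ethoxy group there.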